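This account rests on a few compounds, and the source may have more. Where it says the series, first, only, none or still open, it means among the compounds named here.

Three compounds of a shared core were tested in a functional assay on PC-3 cells (Homo sapiens) for cytotoxicity, read by MTT assay, with a stated time of 72 h; a lower number here means a stronger inhibitor, a higher number a weaker inhibitor. Compound 1 `[O-][n+]1nc(NCOCc2ccccc2)[n+]([O-])c2ccccc21` gives 11900 nM. Compound 2 `CCCOCNc1n[n+]([O-])c2ccccc2[n+]1[O-]` gives 7400 nM. Compound 3 `CCOCNc1n[n+]([O-])c2ccccc2[n+]1[O-]` gives 7400 nM, level with compound 2 at the digits shown, and these two numbers sit together at the low end of the three, with compound 1 the furthest away. The steps among them were small: a 1.6-fold lower number from compound 1 to compound 2 (0.21 log units; within the scatter), a 1.6-fold lower number from compound 1 to compound 3 (0.21 log units; within the scatter), and no change at the digits printed from compound 2 to compound 3 (within the scatter).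

Compound 4 `CCCCCOCNc1n[n+]([O-])c2ccccc2[n+]1[O-]` has not yet been measured in this assay. The change from compound 3 is propyl in place of hydrogen on a saturated chain carbon, two bonds along the chain from an oxygen on a saturated carbon. Within the data shown here, the steps that bear on it are those that altered the same chain next to the oxygen, and none of them moved the number beyond the scatter. The chain lengthening in compound 4 is therefore expected to produce a step of about a 1.2-fold lower number from compound 3 to compound 4 (0.09 log units; within the scatter), with no clear direction beyond the scatter. On that basis compound 4 is estimated at 6000 nM, expected to fall between 2500 nM and 15000 nM.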

Compound 4, half-maximal inhibitory concentration: 8510 nM
For compound 4 the middle estimate is 1.4-fold (0.15 log units) below the measured one, and the stated range covers the measured number.
By their numbers in this assay, from the lowest: compounds 2, 3, 4 and 1 (each within the scatter of the next).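

With compound 4, the chain carries a propyl in place of hydrogen on a saturated chain carbon, two bonds along the chain from an oxygen on a saturated carbon, and in this assay this gives a 1.2-fold higher number from compound 3 to compound 4 (0.06 log units; within the scatter). The other two new comparisons read the same way, with a 1.2-fold higher number from compound 2 to compound 4 (0.06 log units; within the scatter) and a 1.4-fold lower number from compound 1 to compound 4 (0.15 log units; within the scatter), so this pentyloxy chain adds a longer example to the earlier ones, and the number still does not separate from the others beyond the scatter. No outside measurement is available to bear on this result.

The compounds shown leave open whether a chain longer than pentyloxy, or one ending in an amine or a carboxylic acid, would move the number beyond the scatter. They also leave open whether any group at this place can do so.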